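Shortening the thioether chain in a shared oxazoline-triazole series

The compounds below may be only part of what the source reports. "The series", "measured", "known", "first", "only" and "open" are said of these compounds alone.

Measured compounds, in an ADME assay (MDM cells, Homo sapiens) for cytotoxicity, read by resazurin assay, with a stated time of 3 days; on this read-out lower numbers stand for stronger inhibition and higher numbers for weaker inhibition:
Compound 1 `CCOC(=O)CC(=O)CSc1nnc(COc2ccccc2C2=NOC(c3ccc(Cl)cc3Cl)C2)n1NC(=O)CCl`: "not determined" (no result reported)
Compound 2 `CCOC(=O)CC(=O)CSc1nnc(COc2ccccc2C2=NOC(c3ccc(Cl)cc3Cl)C2)n1NC(C)=O`: "not determined" (no result reported)
Compound 3 `CCCCSc1nnc(COc2ccccc2C2=NOC(c3ccc(Cl)cc3Cl)C2)n1NC(=O)c1ccccc1`: 2.5 ug/mL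

For the measured compounds named here, compound 2 has no number of its own in this assay, and the same holds for compound 1, so the only measured anchor is compound 3. Compound 4 `CCSc1nnc(COc2ccccc2C2=NOC(c3ccc(Cl)cc3Cl)C2)n1NC(C)=O` follows from compound 2 through one change: methyl in place of ((ethoxycarbonyl)methyl)carbonyl on a saturated chain carbon bound to a sulfur. No step between measured compounds is shown, so no direction can be drawn from the data; the step in this assay is expected to stay within the usual scatter rather than beyond it. Resting on the value of compound 3 alone, compound 4 is expected to give 4 ug/mL, within a range from 1.2 ug/mL to 15 ug/mL.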

Compound 4, half-maximal inhibitory concentration: 9.7 ug/mL
For compound 4 the middle estimate is 2.4-fold (0.38 log units) below the measured one; low and high end bracket the measured number.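

No new step can be read from compound 4, as compound 2 offers no single number to compare it with. The compounds shown leave open what changing the thioether chain alone does in this assay and no other evidence bears on this result.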